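This account rests on a few compounds, and the source may have more. Where it says the series, first, only, none or still open, it means among the compounds named here.

Of the compounds shown here, two that share one core have so far been read in a physicochemical assay for solubility, read by spectrophotometry, measured as kinetic solubility, at pH 8, tested at 500 uM (on this read-out lower numbers stand for lower solubility and higher numbers for higher solubility), and they sit far apart. Compound 1 `CN(Cc1cncnc1)S(=O)(=O)c1ccccc1Nc1cc(-c2ccc3ccn(C)c3c2)c2nccnc2c1` gives 3 ug/mL in this test, while compound 2 `CC(=O)N1CCC(NC(=O)c2ccncc2Nc2cc(-c3ccc4ccn(C)c4c3)c3nccnc3c2)CC1` gives 213 ug/mL and so holds the higher of the two numbers, by a gap well beyond the scatter of repeat measurements.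

The next compound, compound 3 `CN1CC(NC(=O)c2ccncc2Nc2cc(-c3ccc4ccn(C)c4c3)c3nccnc3c2)C1`, keeps the core and the amide of compound 2 and changes one group. It has 1-methylazetidin-3-yl in place of 1-acetylpiperidin-4-yl on an amide-type nitrogen and nothing else differs.

Going by the values given here, no measured pair of compounds shows what such a swap does in this assay so the expectation is a loose one. With compound 2 at 213 ug/mL as the higher of the two numbers, a small fall looks likelier than a rise, and no step beyond the scatter is expected. The expected change is a 1.6-fold lower number from compound 2 to compound 3 (0.21 log units; within the scatter) by this estimate. For compound 3 the estimated value is 130 ug/mL within an expected range of 40 ug/mL to 240 ug/mL on this read-out.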

Compound 3, solubility: 170 ug/mL
Estimate against measurement, compound 3: 1.3-fold (0.12 log units) below, within the range that was stated.
By their numbers in this assay, from the lowest: compound 1; then compounds 3 and 2 (each within the scatter of the next).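

Putting 1-methylazetidin-3-yl in place of 1-acetylpiperidin-4-yl on the amide-type nitrogen gives a 1.3-fold lower number from compound 2 to compound 3 (0.10 log units; within the scatter) in this assay, so the two numbers cannot be told apart on this read-out. Going by these compounds alone, this is the only step that can be read so far, and it shows that this place tolerates a substantial change in the group without a step beyond the scatter: from 9 heavy atoms to 5, from a six-membered to a four-membered ring, and with the double bond outside aromatic rings gone. Nothing measured here bears on why the two numbers stay so close.

This single step changes ring size and the group on the ring nitrogen together, so it cannot say which of the two matters; 1-methylpiperidin-4-yl or 1-acetylazetidin-3-yl on the same nitrogen would pull them apart. It also leaves open how this assay would respond to groups of another kind at this place, such as an open chain ending in a primary amine or a carboxylic acid.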